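The compounds below may be only part of what the source reports. "The series", "measured", "known", "first", "only" and "open" are said of these compounds alone.

The measured compounds:
compound 1 `Cc1nc(N2CCCCC2)c2nnn(-c3ccc(C(C)C)cc3Br)c2n1`, with 46 nM in an in vitro assay on 293-EBNA cells for binding affinity to corticotropin-releasing factor receptor 1 (Homo sapiens); on this read-out higher numbers stand for weaker inhibition and lower numbers for stronger inhibition
compound 2 `COCC(COC)Nc1nc(C)nc2c1nnn2-c1ccc(C(C)C)cc1Br`, with 10.3 nM
compound 3 `CCCCC(CC)Nc1nc(C)nc2c1nnn2-c1ccc(C(C)C)cc1Br`, with 3.1 nM

Of the three, compound 3 gives the lowest number. Both steps leading to it, a 15-fold lower number from compound 1 to compound 3 (1.17 log units; beyond the scatter) and a 3.3-fold lower number from compound 2 to compound 3 (0.52 log units; beyond the scatter), lie beyond the scatter, so on these numbers compound 3 is the most potent of the set, and the group on this carbon is the only thing that has been varied.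

Compound 4 `CCC(CC)Oc1nc(C)nc2c1nnn2-c1ccc(C(C)C)cc1Br` differs from compound 3 in one place: (pentan-3-yl)oxy in place of (1-ethylpentyl)amino on an aromatic carbon. Among the measured compounds shown here, no measured pair makes a change of this kind, an oxygen in place of the amino nitrogen. For the measured compounds named here, the steps that bear on it are those into compound 3, a 15-fold lower number from compound 1 to compound 3 (1.17 log units; beyond the scatter) and a 3.3-fold lower number from compound 2 to compound 3 (0.52 log units; beyond the scatter), which show that what sits on this carbon moves the number in this assay by a modest to large amount. Because a 15-fold lower number from compound 1 to compound 3 (1.17 log units; beyond the scatter) shows that the whole spread seen so far comes from this position, moving away from the (1-ethylpentyl)amino group is expected to cost something, and the expected step is a 3.2-fold higher number from compound 3 to compound 4 (0.51 log units; beyond the scatter), a rise in the number. Compound 4 is therefore expected to give 10 nM in this assay, within a range of 3 nM to 35 nM.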

Compound 4, inhibition constant: 1.9 nM
Estimate against measurement, compound 4: 5.3-fold (0.72 log units) above, outside the stated range (below it).
By their numbers in this assay, from the lowest: compounds 4 and 3 (each within the scatter of the next); then compound 2; then compound 1.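

In this assay the change to (pentan-3-yl)oxy gives a 1.6-fold lower number from compound 3 to compound 4 (0.21 log units; within the scatter) and so shows that this aromatic carbon accepts a group joined through oxygen, with no hydrogen-bond donor and fewer heavy atoms, as well as the (1-ethylpentyl)amino group. Set against the other two groups, the same (pentan-3-yl)oxy group gives a 5.4-fold lower number from compound 2 to compound 4 (0.73 log units; beyond the scatter) and a 24-fold lower number from compound 1 to compound 4 (1.38 log units; beyond the scatter) on the same read-out, so the lower numbers at this position do not depend on a nitrogen attached to this carbon. No measurement at hand offers an explanation for this result.

The link atom and the chain change together in the step between the two best compounds, and the compounds shown do not separate them: that would take the pairing of (pentan-3-yl)amino with (1-ethylpentyl)oxy on the shared core. Also open, from the compounds shown here alone, is how a sulfur link such as (pentan-3-yl)thio, or a longer chain on the oxygen, would read in this assay.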